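This account rests on a few compounds, and the source may have more. Where it says the series, first, only, none or still open, it means among the compounds named here.

Two measured compounds share the same core. Compound 1 `N#Cc1ccc(Cn2cc(/C=C/C(=O)CC(=O)C(=O)O)c3ccccc32)cc1` gives 1.4 uM in an assay on isolated protein for inhibition of DNA nucleotidylexotransferase (Homo sapiens), read by scintillation counting, with a stated time of 10 min; on this read-out lower numbers stand for stronger inhibition and higher numbers for weaker inhibition. Compound 2 `COc1ccc(Cn2cc(/C=C/C(=O)CC(=O)C(=O)O)c3ccccc32)cc1` gives 10 uM in this assay and so stands highest of the two numbers; the step of a 7.1-fold higher number from compound 1 to compound 2 (0.85 log units; beyond the scatter) is the only measured one, and it swaps one group on the aromatic carbon. The next compound, compound 3 `CN(C)C(=O)Cn1cc(/C=C/C(=O)CC(=O)C(=O)O)c2ccccc21`, carries the change (dimethylcarbamoyl in place of 4-methoxyphenyl on a saturated chain carbon bound to an aromatic nitrogen). Going by the values given here, no measured step bears directly on it, as both measured compounds keep the aryl group that leaves here, so the expectation rests only on the general loss of that group: a weakening is expected, a 3.0-fold higher number from compound 2 to compound 3 (0.48 log units; beyond the scatter). Compound 3 is therefore estimated at 30 uM, within a range of 8 uM to 150 uM.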

Compound 3, concentration for 50% inhibition: 8.9 uM
For compound 3 the middle estimate is 3.4-fold (0.53 log units) above the measured one; measured number inside the range.
By their numbers in this assay, from the lowest: compound 1; then compounds 3 and 2 (each within the scatter of the next).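

At this position in this assay, the aromatic ring can be given up without a reading beyond the scatter when the comparison starts from the 4-methoxyphenyl group: dimethylcarbamoyl in its place gives a 1.1-fold lower number from compound 2 to compound 3 (0.05 log units; within the scatter). Against the 4-cyanophenyl group, the same replacement gives a 6.4-fold higher number from compound 1 to compound 3 (0.80 log units; beyond the scatter), so among these three compounds only compound 1 stands apart. No evidence on the reason for either step is at hand.

Open, on these data alone, is whether an amine or a carboxylic acid in place of dimethylcarbamoyl would reach the level of compound 1. Also open, as far as these compounds go, is whether a sulfonamide on the aromatic carbon would do the same as the nitrile.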